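Thiophen-2-yl in place of 4-fluorophenyl on a carbonyl carbon

The source may hold more compounds than are shown below. What is called first, only, known or untested is meant among the compounds shown, and "the series" means these compounds.

Measured so far in an ADME assay on cells (Hepatocyte, Homo sapiens) for metabolic stability; a higher number here means that the compound lasts longer, a lower number that the compound disappears faster:
- compound 1 `O=C(OC1CCC(CN2CCN(c3cc(=O)c4cc(C(F)(F)F)cc([N+](=O)[O-])c4s3)CC2)CC1)c1ccccc1`: 0.603 h
- compound 2 `CC(=O)OC1CCC(CN2CCN(c3cc(=O)c4cc(C(F)(F)F)cc([N+](=O)[O-])c4s3)CC2)CC1`: < 0.15 h (a limit, not a number)
- compound 3 `O=C(OC1CCC(CN2CCN(c3cc(=O)c4cc(C(F)(F)F)cc([N+](=O)[O-])c4s3)CC2)CC1)c1ccc(F)cc1`: 0.0983 h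

Only two of these results are actual numbers, and compound 3 holds the lower one at 0.0983 h. Its nearest neighbour is compound 1, and the gap between them is a 6.1-fold lower number from compound 1 to compound 3 (0.79 log units; beyond the scatter). Compound 2 gives < 0.15 h, which is a limit of the assay.

The next compound, compound 4 `O=C(OC1CCC(CN2CCN(c3cc(=O)c4cc(C(F)(F)F)cc([N+](=O)[O-])c4s3)CC2)CC1)c1cccs1`, keeps the shared core and changes one group: thiophen-2-yl in place of 4-fluorophenyl on a carbonyl carbon. Thiophen-2-yl thus takes the place of 4-fluorophenyl on a carbonyl carbon.

Going by the values given here, two measured steps bear on this change. Both start from compound 1, which carries a plain phenyl group, and both lead down: a 6.1-fold lower number from compound 1 to compound 3 (0.79 log units; beyond the scatter), and an at least 4.0-fold lower number from compound 1 to compound 2 (0.60 log units; beyond the scatter). Neither tests a thiophen-2-yl group directly, so the forecast is uncertain. Since compound 4 loses the fluoro group, part of the drop seen in a 6.1-fold lower number from compound 1 to compound 3 (0.79 log units; beyond the scatter) is expected to be recovered, but not all of it. A modest rise is therefore expected, an estimated 2.5-fold higher number from compound 3 to compound 4 (0.41 log units; beyond the scatter). For compound 4 the estimated half-life is 0.25 h, with an expected range from 0.08 h to 0.7 h.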

Compound 4, half-life: 0.0917 h
Compound 4: the middle estimate sits 2.7-fold (0.44 log units) above what was measured; the range from low to high includes it.
By their numbers in this assay, from the lowest: compounds 4 and 3 (each within the scatter of the next); then compound 1.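

In this assay, putting thiophen-2-yl in place of 4-fluorophenyl on the carbonyl carbon gives a 1.1-fold lower number from compound 3 to compound 4 (0.03 log units; within the scatter), so this exchange of one aromatic ring for another, although it changes the ring size and brings in a sulfur atom, makes no readable difference to the half-life. Set against the plain phenyl group, the same thiophen-2-yl gives a 6.6-fold lower number from compound 1 to compound 4 (0.82 log units; beyond the scatter), which places compound 4 with compound 3 and leaves compound 1 alone with the longer half-life among the three compounds with an aromatic ring at this position. The steps from compound 2 to compound 3 and to compound 4 cannot be read, since compound 2 carries a limit and not a number: the limit of < 0.15 h in this assay, at which 1 of the 4 values shown sits.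

The compounds shown do not tell why the plain phenyl group stands apart from both 4-fluorophenyl and thiophen-2-yl. From the compounds shown here alone, it also remains open whether a 4-chlorophenyl group, a furan-2-yl ring or a cyclohexyl group on the same carbonyl carbon would fall with compound 1 or with compound 3 and compound 4.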